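This account rests on a few compounds, and the source may have more. Where it says the series, first, only, none or still open, it means among the compounds named here.

For the measured compounds named here, in a functional assay on MV4-11 cells (Homo sapiens) for inhibition, read by resazurin assay, with a stated time of 72 h (on this read-out higher numbers stand for weaker inhibition of growth and lower numbers for stronger inhibition of growth), compound 3 `COc1ccc(Nc2nccc(-c3sc(SCc4cccnc4)nc3C)n2)c(OC)c1` gives 270 nM, the lowest number so far, while compound 2 `COc1ccc(Nc2nccc(-c3sc(OC)nc3C)n2)c(OC)c1` gives 1400 nM and compound 1 `COc1ccc(Nc2nccc(-c3sc(SC(C)C)nc3C)n2)c(OC)c1` gives 5670 nM. Compound 4 `COc1ccc(Nc2nccc(-c3sc(N(C)C)nc3C)n2)c(OC)c1` remains unmeasured. It puts dimethylamino in place of ((pyridin-3-yl)methyl)sulfanyl on an aromatic carbon. Two measured steps introduced that same pyridine-bearing group and lowered the number: a 5.2-fold lower number from compound 2 to compound 3 (0.71 log units; beyond the scatter) and a 21-fold lower number from compound 1 to compound 3 (1.32 log units; beyond the scatter). Removing it should therefore raise the number in this assay, probably by a modest step. The two compounds without it also differ from each other, with a 4.1-fold lower number from compound 1 to compound 2 (0.61 log units; beyond the scatter), so the outcome is uncertain. The expected change is a 5.6-fold higher number from compound 3 to compound 4 (0.74 log units; beyond the scatter). Compound 4 is estimated at 1500 nM, with an expected range of 450 nM to 5000 nM.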

Compound 4, concentration for 50% growth inhibition: 170 nM
Compound 4: the middle estimate sits 8.8-fold (0.95 log units) above what was measured; measured number below the stated range.
By their numbers in this assay, from the lowest: compounds 4 and 3 (each within the scatter of the next); then compound 2; then compound 1.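

In this assay, dimethylamino in place of the ((pyridin-3-yl)methyl)sulfanyl group gives a 1.6-fold lower number from compound 3 to compound 4 (0.20 log units; within the scatter), so at this position a low number does not depend on the pyridine ring. Dimethylamino also separates clearly from the two other groups, with an 8.2-fold lower number from compound 2 to compound 4 (0.92 log units; beyond the scatter) and a 33-fold lower number from compound 1 to compound 4 (1.52 log units; beyond the scatter) in the same direction. The data offer no measured explanation for these differences.

Still open, going by these compounds, is whether other amines on this carbon, such as morpholine or a simple methylamino group, would keep the number this low.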